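The source may hold more compounds than are shown below. What is called first, only, known or untested is meant among the compounds shown, and "the series" means these compounds.

Measured in an ADME assay for permeability, using PAMPA, with a stated time of 4 h, at pH 7.4; a higher number here means that the compound crosses the layer faster, a lower number that the compound crosses the layer more slowly:
- compound 1 `C/C(CN)=C(/F)CN(C[C@H]1Cc2ccccc2CN1)[C@H]1CCCc2cccnc21`: 220 nm/s
- compound 2 `C/C(=C/CN(C[C@H]1Cc2ccccc2CN1)[C@H]1CCCc2cccnc21)CN`: 11 nm/s

Compound 2 is the lower of the two, with a 20-fold lower number from compound 1 to compound 2 (1.30 log units; beyond the scatter), a large step beyond the scatter. Compound 3 `N[C@H]1CC[C@H](CN(C[C@H]2Cc3ccccc3CN2)[C@H]2CCCc3cccnc32)CC1` changes compound 2 on a saturated chain carbon bound to an amine nitrogen: a group of 7 heavy atoms (6 carbon, 1 nitrogen; one six-membered non-aromatic ring of carbon only) in place of a group of 5 heavy atoms (4 carbon, 1 nitrogen; no ring), on a saturated chain carbon bound to an amine nitrogen. The entering 4-aminocyclohexyl group holds a six-membered non-aromatic ring of carbon only. Within the data shown here, the one measured step falls at this same place but swaps different groups, so it shows that the place can matter in this assay without giving a direction. The step expected here is a 1.6-fold higher number from compound 2 to compound 3 (0.21 log units; within the scatter), with little confidence. For compound 3 the estimated value is 18 nm/s, with an expected range of 4 nm/s to 70 nm/s.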

Compound 3, apparent permeability: 12 nm/s
Compound 3: middle estimate off by 1.5-fold (0.18 log units), on the high side; low and high end bracket the measured number.
By their numbers in this assay, from the lowest: compounds 2 and 3 (each within the scatter of the next); then compound 1.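

In this assay, putting 4-aminocyclohexyl in place of the open chain gives a 1.1-fold higher number from compound 2 to compound 3 (0.04 log units; within the scatter), so at this saturated chain carbon bound to an amine nitrogen, the carbon ring and the chain without fluorine read alike. The same ring set against the fluorine-bearing chain of compound 1 gives an 18-fold lower number from compound 1 to compound 3 (1.26 log units; beyond the scatter), which leaves compound 1 alone at the top. Nothing measured here explains that gap.

Still open, on these data alone, is whether a fluorine on the cyclohexyl ring would recover the number of compound 1. Also open, as far as these compounds go, is how 4-hydroxycyclohexyl, with a hydroxyl in place of the amine, would read.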